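A trimethoxyphenyl for the propyl of compound 1

The source may report more compounds than this note shows. Statements on the series, on what has been measured and on what is new or still open speak of the compounds shown alone.

Compound 1 `CCCc1nnc(SCC(=O)c2ccc(Cl)cc2)n1N1C(=O)c2ccccc2C1=O` was tested in a functional assay on PC-3M cells (Homo sapiens) for cytotoxicity, read by MTT assay, with a stated time of 48 h; a lower number here means a stronger inhibitor, a higher number a weaker inhibitor. In this assay compound 1 gives only a limit, > 200000 nM. Two further compounds share its core. Compound 2 `C#CCSc1nnc(CCC)n1N1C(=O)c2ccccc2C1=O` likewise gives a limit in this assay, > 200000 nM. Compound 3 `CCCc1nnc(SC)n1N1C(=O)c2ccccc2C1=O` also gives a limit there, > 200000 nM. All three sit at the same limit (the limit of > 200000 nM in this assay, at which 3 of the 3 values shown sit), so the step from compound 1 to compound 2 a step that the two limits leave unreadable from compound 1 to compound 2, the step from compound 1 to compound 3 a step that the two limits leave unreadable from compound 1 to compound 3 and the step from compound 2 to compound 3 a step that the two limits leave unreadable from compound 2 to compound 3 have no readable size. Compound 4 `COc1cc(-c2nnc(SCC(=O)c3ccc(Cl)cc3)n2N2C(=O)c3ccccc3C2=O)cc(OC)c1OC` differs from compound 1 at another place: 3,4,5-trimethoxyphenyl in place of propyl on an aromatic carbon. For the measured compounds named here, none of the measured steps touches this part of the core, and none has a readable size, so they offer no basis for a direction. Compound 4 is therefore expected, with wide uncertainty, to give about 150000 nM (range 20000 nM to 600000 nM) in this assay, and the step from compound 1 to compound 4 an at least 1.3-fold lower number from compound 1 to compound 4 (0.12 log units; that floor lies within the scatter) is an estimate only.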

Compound 4, half-maximal inhibitory concentration: 20700 nM
Compound 4: the middle estimate sits 7.2-fold (0.86 log units) above what was measured; the measured number falls inside the stated range.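

For the compounds shown here, at the aromatic carbon between two ring nitrogen atoms, the change to 3,4,5-trimethoxyphenyl in place of propyl gives the first readable step in this assay, an at least 9.6-fold lower number from compound 1 to compound 4 (0.98 log units; beyond the scatter). Compound 1 gives only a limit, > 200000 nM, so this step has a floor but no upper end. The steps among compound 1, compound 2 and compound 3, all changes on the saturated chain carbon bound to a sulfur, cannot be read, and only this position has so far moved a value off the limit: the limit of > 200000 nM in this assay, at which 3 of the 4 values shown sit.

The compounds shown do not separate the part played by the phenyl ring from that of its three methoxy groups, which a plain phenyl or a longer chain at this position would help to address. They also leave open whether 3,4,5-trimethoxyphenyl has a similar effect when the sulfur carries the methyl of compound 3 or the propargyl group of compound 2.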